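Fluorine removal on the aryl ring of compound 1

A few compounds are considered here, and "the series" means these few. Any claim that something is new, unique, unknown or untested is made for them only; others in the source may bear on it.

Compound 1 `CN(Cc1cc(C(F)(F)F)cc(C(F)(F)F)c1)C(=O)c1c(-c2ccc(F)cc2)c2cccnc2c(=O)n1C` gives 0.21 nM in an assay on IM-9 cells for binding affinity to Substance-P receptor (Homo sapiens) (on this read-out lower numbers stand for stronger inhibition and higher numbers for weaker inhibition), the lowest of the two numbers in hand. Compound 2 `Cn1c(C(=O)NCc2cc(C(F)(F)F)cc(C(F)(F)F)c2)c(-c2ccc(F)cc2)c2cccnc2c1=O` gives 1.1 nM; the step of a 5.2-fold higher number from compound 1 to compound 2 (0.72 log units; beyond the scatter) shows what hydrogen in place of methyl on an amide-type nitrogen costs. Compound 3 `CN(Cc1cc(C(F)(F)F)cc(C(F)(F)F)c1)C(=O)c1c(-c2ccccc2)c2cccnc2c(=O)n1C` differs from compound 1 by hydrogen in place of fluoro on an aromatic carbon. Going by the values given here, no measured step touches this ring; the only step known concerns the amide nitrogen and does not bear on it. A small step, probably toward a higher number and within or near the scatter, is expected: a 1.9-fold higher number from compound 1 to compound 3 (0.28 log units; within the scatter). Compound 3 is estimated at 0.4 nM, between 0.15 nM and 1.2 nM.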

Compound 3, half-maximal inhibitory concentration: 0.25 nM
Compound 3: middle estimate off by 1.6-fold (0.20 log units), on the high side; the measured number falls inside the stated range.
By their numbers in this assay, from the lowest: compounds 1 and 3 (each within the scatter of the next); then compound 2.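

Replacing fluoro with hydrogen on this aromatic carbon, 4-fluorophenyl to phenyl, gives a 1.2-fold higher number from compound 1 to compound 3 (0.08 log units; within the scatter) in this assay, so fluoro is not required here for a number in this range. The amide-nitrogen change, by contrast, gives a 5.2-fold higher number from compound 1 to compound 2 (0.72 log units; beyond the scatter). No measurement in hand gives a reason for either outcome. Going by these compounds, whether an amine, a carboxylic acid or a methoxy group at this carbon would stay within the scatter of compound 1 remains open. Also open, on these data alone, is whether 4-fluorophenyl to phenyl would read the same on compound 2.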